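Capping a Hydroxy Group with a Methyl

The compounds below may be only part of what the source reports. "The series", "measured", "known", "first", "only" and "open" are said of these compounds alone.

In a functional assay on RPMI-7951 cells (Homo sapiens) for cytotoxicity (on this read-out higher numbers stand for an effect only at larger amounts of compound and lower numbers for an effect already at smaller amounts), compound 1 `Oc1ccc2nc(-c3ccccc3)cc(O)c2c1` gives 3.92 ug/mL. Going by the values given here, this is the higher of the two numbers measured so far, so compound 1 needs the larger amount to show an effect. Compound 2 `Oc1ccc2c(O)cc(-c3ccccc3)nc2c1` gives 0.52 ug/mL, a gap beyond the usual scatter.

Compound 3 `COc1ccc2nc(-c3ccccc3)cc(O)c2c1` differs from compound 1 by one change, hydroxy to methoxy: methyl in place of hydrogen on an oxygen on an aromatic ring. This places a methyl in place of hydrogen on an oxygen on an aromatic ring. Among the compounds with values here, no measured pair shows this change, so there is no direct precedent for the size of its effect. With nothing to indicate a direction, the expected result is a 1.3-fold lower number from compound 1 to compound 3 (0.12 log units; within the scatter), a step within the scatter. Compound 3 is estimated at 3 ug/mL, with an expected range of 0.8 ug/mL to 11 ug/mL.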

Compound 3, half-maximal effective concentration: 0.36 ug/mL
The estimate for compound 3 lay 8.3-fold (0.92 log units) above the measured number; measured number outside the range, below it.
By their numbers in this assay, from the lowest: compounds 3 and 2 (each within the scatter of the next); then compound 1.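

Putting methoxy in place of hydroxy gives an 11-fold lower number from compound 1 to compound 3 (1.04 log units; beyond the scatter) in this assay and so compound 3 shows its effect at a much smaller amount than compound 1 does. Going by these compounds alone, the earlier compounds offered no pair differing in one place, so this is the first sign that the read-out responds to a change at this oxygen on an aromatic ring: a methyl in place of hydrogen is enough to move it well beyond the usual scatter. Nothing at hand explains why the number falls so far.

From the compounds shown here alone, it remains open whether a longer chain such as ethyl on the same oxygen would lower the number as far, or whether an amine in place of the hydroxy would do the same. Also open, going by these compounds, is whether a methyl on the other hydroxy group of the shared core would produce a similar step.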